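A few compounds are considered here, and "the series" means these few. Any claim that something is new, unique, unknown or untested is made for them only; others in the source may bear on it.

Measured compounds:
compound 1 `CSc1ccc(C(=O)/C=C/c2ccc([N+](=O)[O-])o2)cc1` with 40700 nM
compound 2 `Cc1cccc(C(=O)/C=C/c2ccc([N+](=O)[O-])o2)c1` with 55100 nM
compound 3 `CCCCc1ccc(C(=O)/C=C/c2ccc([N+](=O)[O-])s2)cc1` with 81300 nM

All three were read in an ADME assay on Vero cells (Chlorocebus sabaeus) for cytotoxicity, read by resazurin assay, with a stated time of 72 h; on this read-out lower numbers stand for higher toxicity in this test and higher numbers for lower toxicity in this test. Compound 1 sits at the low end of the three numbers, yet compound 2 and compound 3 both lie within the usual scatter of it, so the three cannot really be told apart. Going by the values given here, no pair that differs in only one place has been compared. Compound 4 `O=C(/C=C/c1ccc([N+](=O)[O-])o1)c1ccc(Br)cc1` has not yet been measured. Its change from compound 1 is bromo in place of methylsulfanyl on an aromatic carbon. With nothing to anchor the step, no shift beyond the scatter in this assay is expected in either direction. Compound 4 is therefore estimated at 45000 nM, in a range from 20000 nM to 100000 nM. That estimate means a step of a 1.1-fold higher number from compound 1 to compound 4 (0.04 log units; within the scatter).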

Compound 4, half-maximal cytotoxic concentration: > 100000 nM
Compound 4: only a limit was reported; the forecaster's own chance of this, stated with the estimate: 10%; middle value at least 2.2-fold (0.34 log units) away from the limit.
By their numbers in this assay, from the lowest: compounds 1, 2 and 3 (each within the scatter of the next). At a limit, above all of these: compound 4.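

In this assay, going by these compounds alone, bromo in place of methylsulfanyl on this aromatic carbon, para to a large group, gives an at least 2.4-fold higher number from compound 1 to compound 4 (0.39 log units; beyond the scatter), the first single-place change and one that lies beyond the scatter. Compound 4 reads > 100000 nM, which is a limit of the assay and not a number. The group at this position can therefore shift the reading, but the full size of the shift remains unknown: the limit of > 100000 nM in this assay, at which 1 of the 4 values shown sits.

As far as these compounds go, what an amine, a carboxylic acid or a longer chain at this position would do remains open. So does whether bromo would give a similar step on the core of compound 3.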